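The source may report more compounds than this note shows. Statements on the series, on what has been measured and on what is new or still open speak of the compounds shown alone.

Measured so far in an assay on isolated protein with Bile acid receptor (Homo sapiens) as the target; a higher number here means that more compound is needed for the effect, a lower number that less compound is needed:
compound 1 `COC(=O)/C=C/c1cccc(N(Cc2ccc(/C=C/c3cccc(F)c3)cc2)C(=O)C2CCCCC2)c1`: 86 nM
compound 2 `COC(=O)/C=C/c1cccc(N(Cc2ccc(/C=C/c3scnc3C)cc2)C(=O)C2CCCCC2)c1`: 227 nM
compound 3 `COC(=O)/C=C/c1cccc(N(Cc2ccc(-c3ccc(F)c(F)c3)cc2)C(=O)C2CCCCC2)c1`: 72 nM

Compound 3 gives the lowest of the three numbers, but its gap to compound 1 is small: a 1.2-fold lower number from compound 1 to compound 3 (0.08 log units; within the scatter). Only compound 2 is clearly apart, with a 3.2-fold lower number from compound 2 to compound 3 (0.50 log units; beyond the scatter) and a 2.6-fold higher number from compound 1 to compound 2 (0.42 log units; beyond the scatter). So the terminal aromatic group has been changed twice with little consequence, and once with a modest loss.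

Compound 4 `CCOc1cccc(-c2ccc(CN(C(=O)C3CCCCC3)c3cccc(/C=C/C(=O)OC)c3)cc2)c1` is not yet measured in this assay. The change from compound 3 is 3-ethoxyphenyl in place of 3,4-difluorophenyl on an aromatic carbon, on an aromatic carbon of a six-membered aromatic ring of carbon only, para to a large group. Among the measured compounds shown here, no measured step replaces a fluorinated phenyl by an alkoxyphenyl, so the two steps that touch the same position are the only guide. The step from compound 1 to compound 3 is within the scatter; the step from compound 2 to compound 3 is modest. A small step is therefore expected for compound 4, in either direction, most likely not beyond the scatter, so a 1.4-fold higher number from compound 3 to compound 4 (0.14 log units; within the scatter) is estimated. The estimate for compound 4 in this assay is 100 nM, with a range from 40 nM to 260 nM.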

Compound 4, half-maximal effective concentration: 147 nM
Beside the measured number, compound 4's estimate is 1.5-fold (0.17 log units) below it, and the stated range covers the measured number.
By their numbers in this assay, from the lowest: compounds 3, 1, 4 and 2 (each within the scatter of the next, the first and the last beyond it).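

In this assay, among the compounds shown here, the exchange of 3,4-difluorophenyl for 3-ethoxyphenyl is the first comparison of two substituted phenyl groups with no ethenyl chain in either, and it gives a modest step (a 2.0-fold higher number from compound 3 to compound 4 (0.31 log units; beyond the scatter)), so this position responds to the substituents on the ring even when the ethenyl chain plays no part. The 3-ethoxyphenyl group stays within the scatter of both ethenyl-linked compounds (a 1.5-fold lower number from compound 2 to compound 4 (0.19 log units; within the scatter); a 1.7-fold higher number from compound 1 to compound 4 (0.23 log units; within the scatter)), even though those two lie beyond the scatter of each other, so the four compounds do not divide cleanly into groups with and without the ethenyl chain. No measurement on hand accounts for the step, and the loss of two fluorines cannot be told apart from the entry of the ethoxy group with its one hydrogen-bond acceptor.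

Going by these compounds, it remains open whether the ether oxygen or the ethyl chain carries the step, which a comparison of 3-hydroxyphenyl and 3-propylphenyl at the same place could separate. Also open is how this position responds to a phenyl ring bearing an amine or a carboxylic acid, groups unlike any of the four shown.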